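Methoxy moved on the phenyl at the saturated ring carbon

This account rests on a few compounds, and the source may have more. Where it says the series, first, only, none or still open, it means among the compounds named here.

Measured so far in a functional assay on the whole organism for inhibition, with Rattus norvegicus as the target, read by paw edema, with a stated time of 3 h, at a dose of 50 mg/kg by the oral route; a lower number here means less inhibition, a higher number more inhibition at the dose given (going by the name of the read-out):
Compound 1, `CS(=O)(=O)c1ccc(C2=NN(c3ccc(S(N)(=O)=O)cc3)C(c3ccccc3)C2)cc1`, gives 54.3%.
Compound 2, `CS(=O)(=O)c1ccc(C2=NN(c3ccc(S(N)(=O)=O)cc3)C(c3ccc(Cl)cc3)C2)cc1`, gives 42.4%.
Compound 3, `COc1cccc(C2CC(c3ccc(S(C)(=O)=O)cc3)=NN2c2ccc(S(N)(=O)=O)cc2)c1`, gives 38.3%.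

Compound 3 holds the bottom number of the three, but its gap to compound 2 is within the scatter; only the gap to compound 1 is beyond it. Compound 4, `COc1ccc(C2CC(c3ccc(S(C)(=O)=O)cc3)=NN2c2ccc(S(N)(=O)=O)cc2)cc1`, differs from compound 3 in one place: 4-methoxyphenyl in place of 3-methoxyphenyl on a saturated ring carbon.

Among the compounds with values here, no measured step moves a group from one position to another on that phenyl, so the bearing of the known steps is indirect. Adding chloro or methoxy to the unsubstituted phenyl of compound 1 lowered the number modestly, a number 11.9 percentage points lower from compound 1 to compound 2 (beyond the scatter) and a number 16 percentage points lower from compound 1 to compound 3 (beyond the scatter), while exchanging one substituted phenyl for the other gave a number 4.1 percentage points lower from compound 2 to compound 3 (within the scatter). Since substituted phenyls here sit close together, no step beyond the scatter is expected from compound 3 to compound 4 in this assay, and the expected shift is a number 1.7 percentage points higher from compound 3 to compound 4 (within the scatter).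

Compound 4 is therefore estimated at 40%, with a range from 26% to 54%.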

Compound 4, a percentage reported as inhibition, in the whole organism at one dose (the size of the read-out at that dose, not a potency): 42.4%
Compound 4: middle estimate off by 2.4 percentage points, on the low side; the measured number falls inside the stated range.
By their numbers in this assay, from the lowest: compounds 3, 2 and 4 (each within the scatter of the next); then compound 1.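

In this assay, moving the methoxy from the 3-methoxyphenyl to the 4-methoxyphenyl arrangement on the saturated ring carbon gives a small shift (a number 4.1 percentage points higher from compound 3 to compound 4 (within the scatter)), so the two placements are not told apart here. Methoxy and chloro in the 4-substituted phenyl also read alike (no change at the digits printed from compound 2 to compound 4 (within the scatter)), whereas the unsubstituted phenyl stays apart (a number 11.9 percentage points lower from compound 1 to compound 4 (beyond the scatter)), as it does from compound 2 and compound 3. Nothing available here bears on why these substituted phenyls read together.

Still open, as far as these compounds go, is whether a different substituent on this phenyl, such as an amine or a carboxylic acid, would stay with compound 2, compound 3 and compound 4 or read closer to compound 1. Also open, from the compounds shown here alone, is whether this grouping holds at other doses or times.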